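Methyl to ethyl on the amino group of compound 1

The compounds below may be only part of what the source reports. "The series", "measured", "known", "first", "only" and "open" are said of these compounds alone.

Measured so far:
Compound 1, `CNc1nnc(Cn2c(=O)oc3ccc(C)cc32)s1`, gives 96% in a functional assay on the whole organism with Mus musculus as the target, read by paw edema, with a stated time of 360 min, at a dose of 50 mg/kg by the oral route; on this read-out higher numbers stand for a weaker effect at the one dose given and lower numbers for a stronger effect.
Compound 2, `CCCn1c(Cn2c(=O)oc3ccc(C)cc32)n[nH]c1=S`, gives 160% in this assay.
Compound 3, `Cc1ccc2oc(=O)n(CC(=O)NN)c2c1`, gives 101% in this assay.

Compound 1 carries the smallest of the three numbers. Its nearest neighbour is compound 3, whose number is within the usual scatter of it, so the two cannot be ranked against each other. Compound 2 is the furthest away, with a number beyond the scatter, which reads as a weaker effect at the one dose given.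

The unmeasured compound 4, `CCNc1nnc(Cn2c(=O)oc3ccc(C)cc32)s1`, differs from compound 1 in one place: methyl in place of hydrogen on a saturated chain carbon bound to a nitrogen on an aromatic ring. Among the measured compounds shown here, no pair of measured compounds differing in one place exists in this set, so the size of such a step in this assay has no precedent here.

On that basis no step beyond the scatter is expected in either direction. Compound 4 is expected to give about 100%, with a range from 75% to 135%. The expected step of a number 4 percentage points higher from compound 1 to compound 4 (within the scatter) stays within the scatter.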

Compound 4, a percentage reported as activity, at one dose (the size of the read-out at that dose, not a potency): 94%
Compound 4: middle estimate off by 6 percentage points, on the high side; low and high end bracket the measured number.
By their numbers in this assay, from the lowest: compounds 4, 1 and 3 (each within the scatter of the next); then compound 2.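

In this assay, among the compounds shown here, the change from methylamino to ethylamino gives a number 2 percentage points lower from compound 1 to compound 4 (within the scatter) as the only step that differs in one place. The saturated chain carbon bound to a nitrogen on an aromatic ring therefore accepts an added methyl with no change that can be told from the usual scatter, and compound 1 and compound 4 cannot be ranked against each other. No accompanying measurement bears on this result, so the flat step remains an observation without an explanation.

The compounds shown leave open whether a longer chain such as propyl or butyl, a branched chain such as isopropyl, a cyclopropyl ring, or the unsubstituted amine would keep the read-out in the same place or move it beyond the scatter. For the compounds shown here, with only one step at this position, they also leave open whether the same methyl to ethyl change would behave alike on any other core.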